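From Pyrrolidinyl to Piperidinyl: A Small Structural Step

A few compounds are considered here, and "the series" means these few. Any claim that something is new, unique, unknown or untested is made for them only; others in the source may bear on it.

Measured so far:
compound 1, `CCCCNC(=S)SCc1nc2ccccc2[nH]1`: 2110 nM
compound 2, `O=C(CC(SC(=S)N1CCCC1)c1ccccc1)c1ccccc1`: 1670 nM

In a functional assay on the whole organism for inhibition, with Cicer arietinum as the target, with a stated time of 7 days (a lower number here means a stronger inhibitor, a higher number a weaker inhibitor), compound 2 gives 1670 nM, the lowest of the two numbers. Compound 1 gives 2110 nM in this assay, and the gap between the two lies within the usual scatter, so neither can be called the stronger inhibitor. Compound 3, `O=C(CC(SC(=S)N1CCCCC1)c1ccccc1)c1ccccc1`, differs from compound 2 by piperidin-1-yl in place of pyrrolidin-1-yl on a thiocarbonyl carbon. Among the measured compounds shown here, no measured pair shows this kind of change, so its effect is unknown; a step no larger than the scatter, in either direction, is expected. Compound 3 is therefore estimated at 1500 nM, with a range from 600 nM to 4000 nM, meaning an expected step of a 1.1-fold lower number from compound 2 to compound 3 (0.05 log units; within the scatter).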

Compound 3, half-maximal inhibitory concentration: 1850 nM
Estimate against measurement, compound 3: 1.2-fold (0.09 log units) below; the range from low to high includes it.
By their numbers in this assay, from the lowest: compounds 2, 3 and 1 (each within the scatter of the next).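

Putting piperidin-1-yl in place of pyrrolidin-1-yl on a thiocarbonyl carbon gives a 1.1-fold higher number from compound 2 to compound 3 (0.04 log units; within the scatter) in this assay. Among the compounds shown here, this is the first pair of compounds here that differ in one place, and it shows that swapping the five-membered ring for the six-membered one leaves no change that can be told from the scatter. Nothing available explains this result.

Still open, as far as these compounds go, is whether an open-chain diethylamino group or a morpholin-4-yl ring on the same carbon would behave alike. Changes elsewhere on the shared core also remain unexplored in these compounds.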